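Furan-3-yl in Place of Thiophen-3-yl: Expectation for Compound 3

A few compounds are considered here, and "the series" means these few. Any claim that something is new, unique, unknown or untested is made for them only; others in the source may bear on it.

Measured so far:
Compound 1, `c1ccc(-c2cc(-c3ccsc3)cc(-c3ccccn3)n2)nc1`: 0.000097 ug/mL
Compound 2, `c1ccc(-c2cc(-c3cccs3)cc(-c3ccncc3)n2)nc1`: 0.84 ug/mL

In a functional assay on A498 cells (Homo sapiens) for antiproliferative activity (a higher number here means a weaker inhibitor of growth, a lower number a stronger inhibitor of growth), compound 1 gives 0.000097 ug/mL, the lowest of the two numbers recorded. In this assay compound 2 gives 0.84 ug/mL, a far higher number, beyond the scatter. Compounds 1 and 2 differ from one another in more than one place, so no single step can be read from that pair; their two values stand on their own.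

Compound 3, `c1ccc(-c2cc(-c3ccoc3)cc(-c3ccccn3)n2)nc1`, has not yet been measured in this assay. It differs from compound 1 by furan-3-yl in place of thiophen-3-yl on an aromatic carbon. No measured step of this kind exists among the compounds shown. The step of a 3.1-fold higher number from compound 1 to compound 3 (0.49 log units; beyond the scatter) is therefore expected to be small, leaning toward a somewhat higher number, and may well fall within the scatter. Compound 3 is estimated at 0.0003 ug/mL, with a range from 0.00003 ug/mL to 0.003 ug/mL.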

Compound 3, concentration for 50% growth inhibition: 0.000032 ug/mL
Beside the measured number, compound 3's estimate is 9.4-fold (0.97 log units) above it; the measured number falls inside the stated range.
By their numbers in this assay, from the lowest: compound 3; then compound 1; then compound 2.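

In this assay, furan-3-yl in place of thiophen-3-yl, on an aromatic carbon opposite the ring nitrogen, gives a 3.0-fold lower number from compound 1 to compound 3 (0.48 log units; beyond the scatter), the only single-place step shown at this position. It shows that sulfur in this five-membered aromatic ring can give way to oxygen with no loss of growth inhibition; the number moves modestly lower, by a margin beyond the scatter. Nothing measured here accounts for the direction or size of this step.

Going by these compounds, with only these two groups compared at this position, it remains open whether a phenyl ring, an amine or a longer chain would keep numbers this low. On these data alone, it also remains open whether the same exchange would give a similar step if either of the two pyridin-2-yl groups were replaced.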